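Methoxy in place of chloro: compound 2 to compound 4

A few compounds are considered here, and "the series" means these few. Any claim that something is new, unique, unknown or untested is made for them only; others in the source may bear on it.

For the measured compounds named here, compound 2 `CN(C)C(=O)c1cc2cnc(Nc3ccc(NC(=O)C4(C(=O)Nc5cccc(Cl)c5)CC4)cc3)nc2n1C1CCCC1` stands second highest of the three numbers measured so far. In a functional assay on A549 cells (Homo sapiens) for inhibition, read by CCK-8 assay, with a stated time of 72 h, tested at 10 uM (a higher number here means more inhibition of growth at the concentration tested, a lower number less inhibition of growth), compound 2 gives 90.7%. Compound 1 `CN(C)C(=O)c1cc2cnc(Nc3ccc(NC(=O)C4(C(=O)Nc5ccc(F)cc5)CC4)cc3)nc2n1C1CCCC1`, which carries the same core, gives 102% in this assay. Compound 3 `Nc1ccc(NC(=O)C2(C(=O)Nc3ccc(F)cc3)CC2)cc1F`, a smaller structure without that core, gives 14.6% in the same read-out and lies far lower than the other two.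

Compound 4 `COc1cccc(NC(=O)C2(C(=O)Nc3ccc(Nc4ncc5cc(C(=O)N(C)C)n(C6CCCC6)c5n4)cc3)CC2)c1` departs from compound 2 in one place: methoxy in place of chloro on an aromatic carbon. This puts methoxy in place of chloro on an aromatic carbon, meta to a large group, so 3-chlorophenyl becomes 3-methoxyphenyl.

Going by the values given here, only one measured step bears on this change. It is a number 11.3 percentage points lower from compound 1 to compound 2 (beyond the scatter), where 3-chlorophenyl replaces 4-fluorophenyl on an amide-type nitrogen. That step is modest, though beyond the scatter, and it alters the same aryl group as the present change. Among the compounds with values here, no measured compound carries methoxy, so the data give no direction for this exchange. Given the modest size of that one step, no change beyond the scatter is expected, and the estimated step is a number 0.7 percentage points lower from compound 2 to compound 4 (within the scatter). A somewhat larger fall remains possible. For compound 4 the expected value in this assay is 90%, with an estimated range of 73% to 104%.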

Compound 4, percent growth inhibition at one concentration: 96%
The estimate for compound 4 lay 6 percentage points below the measured number; the range from low to high includes it.
By their numbers in this assay, from the lowest: compound 3; then compounds 2, 4 and 1 (each within the scatter of the next, the first and the last beyond it).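

In this assay, methoxy in place of chloro on an aromatic carbon, meta to a large group, gives a number 5.3 percentage points higher from compound 2 to compound 4 (within the scatter) and so shows that this position takes methoxy, with the hydrogen-bond acceptor that chloro lacks, without a change beyond the scatter. The comparison with the 4-fluorophenyl compound gives a number 6 percentage points lower from compound 1 to compound 4 (within the scatter) for the 3-methoxyphenyl group, whereas a number 11.3 percentage points lower from compound 1 to compound 2 (beyond the scatter) for 3-chlorophenyl lay beyond the scatter, so in this series only the chloro compound is separated from compound 1 by this aryl exchange. Nothing in the data on hand gives a reason for either reading.

Compound 4 gives 96% in this assay and this single concentration may therefore hide differences among the three compounds with the shared core, which a full concentration series could separate. Also open, from the compounds shown here alone, is whether an amine, a carboxylic acid or a longer chain such as ethoxy on this aromatic carbon would stay within the scatter of compound 4 or fall towards the low value of compound 3 at 14.6% without the core.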